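The source may report more compounds than this note shows. Statements on the series, on what has been measured and on what is new or still open speak of the compounds shown alone.

All four compounds share one core and differ only at the end of a short chain that hangs from an amide-type nitrogen. In an assay on HEK293 cells for displacement of a labelled ligand from NPC1-like intracellular cholesterol transporter 1 (Homo sapiens) (a lower number here means a stronger inhibitor, a higher number a weaker inhibitor), compound 1 `CC(C)(C)c1ccc(C(=O)N2CCC3(CC2)C(=O)N(CC(=O)NCCC(=O)O)CN3c2ccccc2)cc1` gives 11400 nM. Compound 2 `CC(C)(C)OC(=O)NCCCNC(=O)CN1CN(c2ccccc2)C2(CCN(C(=O)c3ccc(C(C)(C)C)cc3)CC2)C1=O` has its chain end changed, and in this assay compound 2 gives 4500 nM; the move is a 2.5-fold lower number from compound 1 to compound 2 (0.40 log units; beyond the scatter). Compound 3 `COC(=O)CCCNC(=O)CN1CN(c2ccccc2)C2(CCN(C(=O)c3ccc(C(C)(C)C)cc3)CC2)C1=O` has a further chain end, and in this assay compound 3 gives "not determined" (no result reported), so it stands without a number.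

Compound 4 `CC(C)(C)c1ccc(C(=O)N2CCC3(CC2)C(=O)N(CC(=O)NCCCCNS(C)(=O)=O)CN3c2ccccc2)cc1` differs from compound 3 by (methanesulfonamido)methyl in place of methoxycarbonyl on a saturated chain carbon, three bonds along the chain from an amide-type nitrogen. Going by the values given here, the only measured step that speaks to this kind of change is the one from compound 1 to compound 2, which also swaps the group at the chain end and was only modest. A change of similar size, in either direction, is therefore expected here, and with compound 3 unmeasured the anchor is the spread of compound 1 and compound 2. Compound 4 is expected to give about 5500 nM in this assay, with a likely range from 1800 nM to 17000 nM.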

Compound 4, half-maximal inhibitory concentration: 4500 nM
Estimate against measurement, compound 4: 1.2-fold (0.09 log units) above; low and high end bracket the measured number.
By their numbers in this assay, from the lowest: compounds 2 and 4 (each within the scatter of the next); then compound 1.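

Swapping the carboxy end of compound 1 for 2-(methanesulfonamido)ethyl on this chain gives, in this assay, a 2.5-fold lower number from compound 1 to compound 4 (0.40 log units; beyond the scatter) and matches the size of the earlier step away from that carboxy end. Setting (methanesulfonamido)methyl in place of (tert-butoxycarbonyl)amino gives no change at the digits printed from compound 2 to compound 4 (within the scatter) so at this position two quite different chain ends cannot be told apart, and compound 1 alone stands apart from them. No supporting data are available to explain why these chain ends give these numbers.

Compound 3 has no number, so its methoxycarbonyl end cannot be placed and steps to it cannot be read. From the compounds shown here alone, whether a free amine at the chain end, or a carboxylic acid on a longer chain, would shift the number in this assay remains open.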